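This account rests on a few compounds, and the source may have more. Where it says the series, first, only, none or still open, it means among the compounds named here.

Measured compounds:
Compound 1, `COc1ncnc2c1c(-c1ccsc1)cn2[C@@H]1O[C@H](CO)[C@@H](O)[C@H]1O`: 64300 nM
Compound 2, `COc1nc(N)nc2c1c(-c1ccsc1)cn2[C@@H]1O[C@H](CO)[C@@H](O)[C@H]1O`: > 100000 nM, a limit of the assay
Compound 3, `O=c1[nH]cnc2c1c(-c1ccco1)cn2[C@@H]1O[C@H](CO)[C@@H](O)[C@H]1O`: > 100000 nM, a limit of the assay

In an ADME assay on BJ cells (Homo sapiens), read by MTT assay, with a stated time of 72 h (on this read-out higher numbers stand for weaker inhibition and lower numbers for stronger inhibition), compound 1 gives 64300 nM. Compound 2 does not give a number in this assay but only its limit, > 100000 nM. Compound 3 likewise gives only the limit, > 100000 nM.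

The change from compound 1 to compound 2 is amino in place of hydrogen on an aromatic carbon. It produced an at least 1.5-fold higher number from compound 1 to compound 2 (0.19 log units; that floor lies within the scatter); the step can be stated only as a floor because of the limit of > 100000 nM in this assay, at which 2 of the 3 values shown sit.

Compound 4, `Nc1nc2c(c(-c3ccco3)cn2[C@@H]2O[C@H](CO)[C@@H](O)[C@H]2O)c(=O)[nH]1`, is not yet measured. It is related to compound 3 by amino in place of hydrogen on an aromatic carbon. Going by the values given here, this is the same kind of change as the one from compound 1 to compound 2, though the surroundings differ: in compound 3 the carbon is meta to a group of 1 heavy atom, whereas in compound 1 it is meta to a methoxy group (2 heavy atoms). How the core of compound 3 differs from the core of compound 1 is not broken down here.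

Compound 3 already sits at the limit, and the earlier amino change did not lower the number, so the step from compound 3 to compound 4 in this assay is expected to be about a step that the limit leaves unreadable from compound 3 to compound 4. Compound 4 is therefore estimated at 150000 nM, most likely reported only as a limit, within a range from 60000 nM to 400000 nM.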

Compound 4, half-maximal inhibitory concentration: > 100000 nM
Compound 4: no number, only a limit; the forecaster's own chance of this, stated with the estimate: 75%; the middle value is on the limit's open side.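

Going by these compounds alone, compound 3 and compound 4 both give only a limit in this assay, so no step between them can be read, because both values sit at the same ceiling: the limit of > 100000 nM in this assay, at which 3 of the 4 values shown sit. The compounds shown leave open how far amino in place of hydrogen on an aromatic carbon moves the number in either pair, and where compound 3 and compound 4 lie beyond that limit.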